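Swapping a trifluoromethylphenyl for a hydroxyphenyl on the amide chain

The source may report more compounds than this note shows. Statements on the series, on what has been measured and on what is new or still open speak of the compounds shown alone.

The measured compounds and their values in an assay on HEK293 cells for displacement of a labelled ligand from Melanocortin receptor 4 (Homo sapiens); a higher number here means a weaker inhibitor, a lower number a stronger inhibitor:
Compound 1 `CCC(C)C(N)c1cc(C(F)(F)F)ccc1N1CCN(C(=O)CCc2ccc(Cl)cc2Cl)CC1` gives 160 nM.
Compound 2 `CC(C)C[C@H](N)c1cc(C(F)(F)F)ccc1N1CCN(C(=O)CCc2ccccc2O)CC1` gives 3300 nM.
Compound 3 `CC(C)C[C@H](N)c1cc(C(F)(F)F)ccc1N1CCN(C(=O)CCc2cccc(C(F)(F)F)c2)CC1` gives 2200 nM.

Compound 3 stands second highest of the three numbers in this assay. Its nearest neighbour is compound 2, and the gap between them is within the scatter; the furthest is compound 1, whose number is far lower, well beyond the scatter. Compound 4 `CC(C)C[C@H](N)c1cc(C(F)(F)F)ccc1N1CCN(C(=O)CCc2ccc(O)cc2)CC1` has not yet been measured. It differs from compound 3 in one place: 4-hydroxyphenyl in place of 3-(trifluoromethyl)phenyl on a saturated chain carbon, two bonds along the chain from a carbonyl carbon.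

Among the measured compounds shown here, one measured step touches the same position: a 1.5-fold lower number from compound 2 to compound 3 (0.18 log units; within the scatter). That step exchanged one substituted phenyl for another at the same chain carbon and moved the number only within the scatter. The new 4-hydroxyphenyl resembles the 2-hydroxyphenyl of compound 2 more than the group it replaces, so compound 4 is expected to land close to compounds 2 and 3, with the step of a 1.4-fold higher number from compound 3 to compound 4 (0.13 log units; within the scatter) estimated to stay within the scatter. For compound 4 the expected value in this assay is 3000 nM, with a likely range from 1000 nM to 9000 nM.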

Compound 4, inhibition constant: > 10000 nM
Compound 4: a limit, no number (the forecaster's own chance of this, stated with the estimate: 5%); at least 3.3-fold (0.52 log units) between middle value and limit.
By their numbers in this assay, from the lowest: compound 1; then compounds 3 and 2 (each within the scatter of the next). At a limit, above all of these: compound 4.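

In this assay compound 4 gives > 10000 nM, which is a limit of the assay and not a number. The earlier exchange of one substituted phenyl for another stayed within the scatter, but this change gives an at least 4.5-fold higher number from compound 3 to compound 4 (0.65 log units; beyond the scatter), and putting 4-hydroxyphenyl in place of 2-hydroxyphenyl gives an at least 3.0-fold higher number from compound 2 to compound 4 (0.48 log units; beyond the scatter). The number at this chain carbon therefore does depend on the phenyl group it carries, and the two hydroxyphenyl groups are not interchangeable, with each step's true size known only as a lower bound.

From the compounds shown here alone, what remains open is whether the hydroxyl itself or its place on the ring matters more, a question that a 4-methoxyphenyl or a 3-hydroxyphenyl at the same chain carbon could address. Compound 1 differs from the others in more than one place, so its much lower number cannot be credited to its phenyl group alone.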